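Triazole-linked sulfonamides: removing the ortho methyl

The source may hold more compounds than are shown below. What is called first, only, known or untested is meant among the compounds shown, and "the series" means these compounds.

Measured so far in a functional assay on HepG2 cells (Homo sapiens) for cytotoxicity, read by MTT assay, with a stated time of 48 h; on this read-out higher numbers stand for weaker inhibition and lower numbers for stronger inhibition:
compound 1 `COc1cc2c(cc1OC)CN(S(=O)(=O)c1ccc(-n3cc(COc4ccc(C=O)cc4)nn3)cc1)CC2`: 12500 nM
compound 2 `COc1cc2c(cc1OC)CN(S(=O)(=O)c1ccc(-n3cc(COc4ccc(C)cc4)nn3)cc1)CC2`: 560 nM
compound 3 `COc1cc2c(cc1OC)CN(S(=O)(=O)c1ccc(-n3cc(COc4ccccc4C)nn3)cc1)CC2`: 1480 nM

Compound 3 stands second highest of the three numbers. Its nearest neighbour is compound 2, the step being a 2.6-fold higher number from compound 2 to compound 3 (0.42 log units; beyond the scatter); its furthest is compound 1, with an 8.4-fold lower number from compound 1 to compound 3 (0.93 log units; beyond the scatter). The largest movement in the set is a 22-fold lower number from compound 1 to compound 2 (1.35 log units; beyond the scatter), a swap of the group on the aromatic carbon.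

Compound 4 `COc1cc2c(cc1OC)CN(S(=O)(=O)c1ccc(-n3cc(COc4ccccc4)nn3)cc1)CC2` differs from compound 3 by hydrogen in place of methyl on an aromatic carbon. Within the data shown here, no measured step removes a methyl altogether; the steps recorded concern formyl against methyl and the position of the methyl on the ring. The position step a 2.6-fold higher number from compound 2 to compound 3 (0.42 log units; beyond the scatter) is modest, so a methyl in this place has only a limited hold on the number, and its loss is expected to move the read-out little in this assay. The expected step is a 1.2-fold lower number from compound 3 to compound 4 (0.09 log units; within the scatter), with direction uncertain and a change within or just beyond the scatter most likely. Compound 4 is therefore estimated at 1200 nM, within 500 nM to 3000 nM.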

Compound 4, half-maximal inhibitory concentration: 2570 nM
Estimate against measurement, compound 4: 2.1-fold (0.33 log units) below; measured number inside the range.
By their numbers in this assay, from the lowest: compound 2; then compounds 3 and 4 (each within the scatter of the next); then compound 1.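

In this assay, taking off the methyl ortho to a large group gives a 1.7-fold higher number from compound 3 to compound 4 (0.24 log units; within the scatter) and leaves 2-methylphenoxy and phenoxy indistinguishable on this read-out, something the comparison of the two methyl positions could not show. Phenoxy now serves as a reference for the other groups on this ring: the methyl of compound 2 separates from hydrogen, with a 4.6-fold higher number from compound 2 to compound 4 (0.66 log units; beyond the scatter) on that swap, and the formyl of compound 1 separates in the opposite direction, with a 4.9-fold lower number from compound 1 to compound 4 (0.69 log units; beyond the scatter) on that swap, so the two groups lie on opposite sides of hydrogen while the methyl of compound 3 stays within the scatter of it. Nothing available accounts for any of these differences.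

The compounds shown leave open whether the separation of compound 2 from compound 4 is particular to methyl or would also appear with a chlorine, a methoxy or an ethyl on the same ring. They also leave open whether the opposite movement seen with formyl extends to a carboxylic acid, a nitrile or an amine.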